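Replacing a ring with an open chain on a carbonyl

The compounds below may be only part of what the source reports. "The series", "measured", "known", "first", "only" and "open" are said of these compounds alone.

Measured so far in a functional assay on HeLa cells (Homo sapiens) for cytotoxicity, read by MTT assay; a lower number here means a stronger inhibitor, a higher number a weaker inhibitor:
compound 1 `CC(C)=CC[C@@H](OC[C@@H](C)O)C1=CC(=O)c2c(O)ccc(O)c2C1=O`: 22500 nM
compound 2 `CC(C)=CC[C@@H](OC(=O)C1CCOC1)C1=CC(=O)c2c(O)ccc(O)c2C1=O`: 73500 nM

Of these two, compound 2 has the higher number, 73500 nM, which makes it the weaker inhibitor. Compound 3 `CCCC(C)(O)CC(=O)O[C@H](CC=C(C)C)C1=CC(=O)c2c(O)ccc(O)c2C1=O` keeps the shared core but changes the group on the carbonyl carbon: 2-hydroxy-2-methylpentyl in place of oxolan-3-yl on a carbonyl carbon. The incoming chain carries a hydroxy group, as the 2-hydroxypropyl of compound 1 does. Going by the values given here, only one measured step bears on this, a 3.3-fold higher number from compound 1 to compound 2 (0.51 log units; beyond the scatter), and it is modest, though beyond the scatter. That step is a different structural change, so it is only a loose guide. In this assay a modest fall in the number is therefore expected, a 2.1-fold lower number from compound 2 to compound 3 (0.32 log units; beyond the scatter). Compound 3 is estimated at 35000 nM, with an expected range from 12000 nM to 90000 nM.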

Compound 3, half-maximal inhibitory concentration: 72000 nM
Estimate against measurement, compound 3: 2.1-fold (0.31 log units) below; the range from low to high includes it.
By their numbers in this assay, from the lowest: compound 1; then compounds 3 and 2 (each within the scatter of the next).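

In this assay the change on the carbonyl carbon gives a 1.0-fold lower number from compound 2 to compound 3 (0.01 log units; within the scatter) and so stays within the scatter: at this position, the open 2-hydroxy-2-methylpentyl chain, with its hydrogen-bond donor, cannot be told apart from the oxolan-3-yl ring. A hydroxy group on the incoming chain also does not bring the number back to that of compound 1, since the full change on that oxygen gives a 3.2-fold higher number from compound 1 to compound 3 (0.51 log units; beyond the scatter) and so lies beyond the scatter. No measurement here accounts for either result.

A plain pentyl chain without the hydroxy group would show whether that hydroxy group matters at all on this carbonyl carbon. Going by these compounds, whether an amine or a carboxylic acid at the same place would move the number also remains open.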